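This account rests on a few compounds, and the source may have more. Where it says the series, first, only, none or still open, it means among the compounds named here.

Measured compounds:
- Compound 1 `CC(C)Oc1cc(Oc2ccc(S(C)(=O)=O)cc2)cc(-c2ccnc(=O)[nH]2)c1`: "not determined" (no result reported)
- Compound 2 `Cc1cnc(-c2cc(Oc3ccc(S(C)(=O)=O)cc3)cc(OC(C)C)c2)[nH]c1=O`: 17 10^-6 cm/s

In an ADME assay on MDCK-II cells (Canis lupus familiaris) for permeability (on this read-out lower numbers stand for lower permeability and higher numbers for higher permeability), compound 2 gives 17 10^-6 cm/s. Going by the values given here, this is the only number available, as no result was reported for compound 1, so compound 2 cannot yet be ranked against anything.

The next compound to be tested is compound 3 `CCc1cnc(-c2cc(Oc3ccc(S(C)(=O)=O)cc3)cc(OC(C)C)c2)[nH]c1=O`. Its structure differs from that of compound 2 by one small change: methyl in place of hydrogen on a saturated chain carbon bound to an aromatic carbon. In words, this is methyl in place of hydrogen on a saturated chain carbon bound to an aromatic carbon, which turns methyl to ethyl.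

Among the compounds with values here, no pair of measured compounds shows what a change of this kind does in this assay, so there is no direct guide to its size. With nothing to suggest otherwise, the step of a 1.1-fold higher number from compound 2 to compound 3 (0.02 log units; within the scatter) is expected to stay within the usual scatter, with no clear direction. For compound 3 the expected value is 18 10^-6 cm/s, with an estimated range of 9 10^-6 cm/s to 32 10^-6 cm/s.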

Compound 3, apparent permeability: 4 10^-6 cm/s
The estimate for compound 3 lay 4.5-fold (0.65 log units) above the measured number; measured number outside the range, below it.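

In this assay, the change from methyl to ethyl goes with a 4.3-fold lower number from compound 2 to compound 3 (0.63 log units; beyond the scatter), a step larger than repeated measurements would normally produce. Going by these compounds alone, this shows that the read-out can respond clearly to one added carbon at this place, on a saturated chain carbon bound to an aromatic carbon, which could not be seen while compound 2 held the only number. Nothing available here accounts for the fall, so this remains an observation from one pair of compounds.

Going by these compounds, it remains open whether a longer chain such as propyl would take the number lower still, or whether a different group, such as an amine or a carboxylic acid, would shift it in either direction. It is equally unknown whether methyl to ethyl would give a step of this size at another place on the shared core.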